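Terminal Formyl Replaces Acetamidomethyl on a Long Chain

A few compounds are considered here, and "the series" means these few. Any claim that something is new, unique, unknown or untested is made for them only; others in the source may bear on it.

The measured compounds:
compound 1, `CCCCCOCCCCCCC/C=C1\CC(CO)(COC(=O)C(C)(C)C)OC1=O`: 3 ug/mL
compound 2, `CC(=O)OCCCCCCCCCCCCCCC/C=C1\CC(CO)(COC(=O)C(C)(C)C)OC1=O`: > 10 ug/mL
compound 3, `CC(=O)NCCCCCCCCCCCCCCC/C=C1\CC(CO)(COC(=O)C(C)(C)C)OC1=O`: > 10 ug/mL

In a functional assay on Hs-578T cells (Homo sapiens) for antiproliferative activity (a lower number here means a stronger inhibitor of growth, a higher number a weaker inhibitor of growth), compound 3 gives only a limit, > 10 ug/mL, so its true value is not known. Compound 2 also sits at a limit, > 10 ug/mL, as noted in the limit of > 10 ug/mL in this assay, at which 2 of the 3 values shown sit. Compound 4, `CC(C)(C)C(=O)OCC1(CO)C/C(=C\CCCCCCCCCCCCCCC=O)C(=O)O1`, differs from compound 3 by formyl in place of acetamidomethyl on a saturated chain carbon, ten or more bonds along the chain from a double-bonded chain carbon. For the measured compounds named here, the steps that bear on this are an at least 3.3-fold higher number from compound 1 to compound 2 (0.52 log units; beyond the scatter) and an at least 3.3-fold higher number from compound 1 to compound 3 (0.52 log units; beyond the scatter), both showing that long chains ending in acetoxy or acetamido reach the limit, while a step that the two limits leave unreadable from compound 2 to compound 3 is unreadable. Formyl is neither group, so the direction is uncertain. Compound 4 is estimated at 5 ug/mL (range 1.5 ug/mL to 15 ug/mL), which is expected to mean an at least 2.0-fold lower number from compound 3 to compound 4 (0.30 log units; that floor lies within the scatter).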

Compound 4, concentration for 50% growth inhibition: > 10 ug/mL
Compound 4: only a limit was reported; the forecaster's own chance of this, stated with the estimate: 35%; middle value at least 2.0-fold (0.30 log units) from the limit.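

In this assay compound 4 gives > 10 ug/mL, which is a limit and not a number. Formyl on a saturated chain carbon thus joins acetoxy and acetamido among the chain ends that reach the limit, with an at least 3.3-fold higher number from compound 1 to compound 4 (0.52 log units; beyond the scatter). The steps among compound 2, compound 3 and compound 4 cannot be read: the limit of > 10 ug/mL in this assay, at which 3 of the 4 values shown sit.

Still open, going by these compounds, is how a carboxylic acid or an amine at the end of the long chain would read in this assay. Also open, on these data alone, is whether a shorter chain ending in formyl would come back to the level of compound 1.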